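The source may report more compounds than this note shows. Statements on the series, on what has been measured and on what is new or still open speak of the compounds shown alone.

Of the compounds shown here, three have been measured in a functional assay on the whole organism (Abdomen, strain Swiss) for inhibition, with Mus musculus as the target, with stated times of 30 min, 10 min and 5 min, at a dose of 20 mg/kg by the oral route; a higher number here means a stronger effect of the compound at the dose given, a lower number a weaker effect. Compound 1 `CCc1nn(CCCN2CCN(c3ccc(C)cc3)CC2)c(=O)c(N)c1C(C)=O` gives 42% in this assay. Compound 2 `COc1cccc(N2CCN(CCCn3nc(-c4ccccc4)c(C#N)c3C)CC2)c1` gives 21%. Compound 3 `CC(=O)c1cccn1CCCN1CCN(c2ccc(F)cc2)CC1` gives 16%, the lowest of the three numbers; its nearest neighbour is compound 2, higher by an amount within the scatter, while compound 1 stands beyond the scatter above it. Compound 4 `COc1cccc(N2CCN(CCCn3cccc3C(C)=O)CC2)c1` has not yet been measured in this assay. It differs from compound 3 as follows: 3-methoxyphenyl in place of 4-fluorophenyl on an amine nitrogen in a ring. Compound 2 already carries the 3-methoxyphenyl group, and its value sits within the scatter of compound 3, so no step beyond the scatter is expected in this assay; the estimated step of a number 2 percentage points higher from compound 3 to compound 4 (within the scatter) is small. Compound 4 is therefore expected to give about 18%, between 5% and 33%.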

Compound 4, a percentage reported as inhibition, in the whole organism at one dose (the size of the read-out at that dose, not a potency): 26%
Estimate against measurement, compound 4: 8 percentage points below, and the stated range covers the measured number.
By their numbers in this assay, from the lowest: compounds 3, 2 and 4 (each within the scatter of the next); then compound 1.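

In this assay, 3-methoxyphenyl in place of 4-fluorophenyl on an amine nitrogen in a ring gives a number 10 percentage points higher from compound 3 to compound 4 (within the scatter). Among the compounds shown here, this is the first comparison in which only this group changes, and it shows that a group with one hydrogen-bond acceptor can replace one with none here without a step beyond the scatter. Nothing at hand accounts for the size of this step.

From the compounds shown here alone, whether a pyridyl or a hydroxyphenyl group at this place would give a step beyond the scatter remains open, as does whether the same exchange would behave alike on the core of compound 1.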